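Exchanging the Aromatic Group of Compound 3

This account rests on a few compounds, and the source may have more. Where it says the series, first, only, none or still open, it means among the compounds named here.

In a functional assay on HepG2 cells (Homo sapiens) for inhibition, read by MTT assay, with a stated time of 72 h (on this read-out lower numbers stand for stronger inhibition and higher numbers for weaker inhibition), compound 1 `CNC(=O)CCCCCCCn1nc(-c2cnc3[nH]ccc3c2)c2c(N)ncnc21` gives 5630 nM, compound 2 `Nc1ncnc2c1c(-c1cnc3[nH]ccc3c1)nn2CCCCCC(=O)NO` gives 12900 nM and compound 3 `Nc1nc2cc(-c3nn(CCCCCCCCCC(=O)NO)c4ncnc(N)c34)ccc2o1` gives 28600 nM. Compound 3 therefore stands highest of the three, with the weakest inhibition in this small set. Compound 4 `Nc1ncnc2c1c(-c1cnc3[nH]ccc3c1)nn2CCCCCCCCCC(=O)NO` keeps the chain of compound 3 and differs only in the aromatic group on the shared core: a group of 9 heavy atoms (7 carbon, 2 nitrogen; one five-membered aromatic ring with 1 hetero atom, one six-membered aromatic ring with 1 hetero atom) in place of a group of 10 heavy atoms (7 carbon, 2 nitrogen, 1 oxygen; one five-membered aromatic ring with 2 hetero atoms, one six-membered aromatic ring of carbon only), on an aromatic carbon. Among the measured compounds shown here, the 2-amino-1,3-benzoxazol-5-yl group leaves, and the group that enters is the one already carried by compound 1 and compound 2.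

For the measured compounds named here, no measured step covers this exchange directly. Going by the values given here, the only step available, a 2.3-fold higher number from compound 1 to compound 2 (0.36 log units; beyond the scatter), concerns the chain and its end rather than this place on the core. It is modest, though beyond the scatter, and it offers only a rough guide to size. With the entering group and the chain end of compound 4, compound 2 gives 12900 nM. A modest move towards a lower number in this assay is therefore expected, though the uncertainty is wide. The estimated change is a 2.6-fold lower number from compound 3 to compound 4 (0.41 log units; beyond the scatter). The expected value for compound 4 is 11000 nM, with an estimated range of 3500 nM to 30000 nM.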

Compound 4, half-maximal inhibitory concentration: 11700 nM
Estimate against measurement, compound 4: 1.1-fold (0.03 log units) below, and the stated range covers the measured number.
By their numbers in this assay, from the lowest: compound 1; then compounds 4 and 2 (each within the scatter of the next); then compound 3.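

In this assay the exchange of the 2-amino-1,3-benzoxazol-5-yl group for the entering group, with the chain unchanged, gives a 2.4-fold lower number from compound 3 to compound 4 (0.39 log units; beyond the scatter), so this place on the shared core now has a measured step of its own and the aromatic group alone shifts the number by a modest amount beyond the scatter. With the entering group held constant, 4-(hydroxycarbamoyl)butyl in place of hydroxycarbamoyl gives a 1.1-fold lower number from compound 2 to compound 4 (0.04 log units; within the scatter), which lies within the scatter, while 2-(hydroxycarbamoyl)ethyl in place of methylcarbamoyl gives a 2.1-fold higher number from compound 1 to compound 4 (0.32 log units; beyond the scatter), a modest step beyond the scatter that leaves compound 1 with the lowest number of the set. Nothing presented here accounts for these differences in terms of mechanism or measured properties.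

Going by these compounds, the exchange is seen on a single chain, so it remains open whether it would have the same size with the shorter chain of compound 2 or the methylcarbamoyl end of compound 1. On these data alone, how a phenyl group at this place on the core, or a carboxylic acid at the chain end, would read in this assay also remains open.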